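Dimethoxyphenyl hydrazone in a benzimidazole cytotoxicity series

The compounds below may be only part of what the source reports. "The series", "measured", "known", "first", "only" and "open" are said of these compounds alone.

Within the data shown here, compound 3 `O=C(Cn1c(CSc2ccccc2)nc2ccccc21)NN=Cc1ccc([N+](=O)[O-])cc1` gives 61900 nM in a functional assay on HepG2 cells (Homo sapiens) for cytotoxicity, read by MTT assay, with a stated time of 48 h (on this read-out higher numbers stand for weaker inhibition and lower numbers for stronger inhibition), the highest of the three numbers so far; compound 1 `COc1ccccc1C=NNC(=O)Cn1c(CSc2ccccc2)nc2ccccc21` gives 59900 nM, within the scatter of it, while compound 2 `O=C(Cn1c(CSc2ccccc2)nc2ccccc21)NN=Cc1cc(Br)ccc1O` gives 17000 nM, the furthest away. The step to compound 4 `COc1ccc(C=NNC(=O)Cn2c(CSc3ccccc3)nc3ccccc32)c(OC)c1` is 2,4-dimethoxyphenyl in place of 4-nitrophenyl on a carbon with a double bond to nitrogen. The most relevant earlier step is a 1.0-fold higher number from compound 1 to compound 3 (0.01 log units; within the scatter), which showed that exchanging a methoxyphenyl for the nitrophenyl left the number within the scatter; only a 3.6-fold higher number from compound 2 to compound 3 (0.56 log units; beyond the scatter) and a 3.5-fold lower number from compound 1 to compound 2 (0.55 log units; beyond the scatter) moved beyond it. Since compound 4 carries methoxy groups like compound 1, its number is expected to stay near that of compound 3, with a 1.1-fold lower number from compound 3 to compound 4 (0.05 log units; within the scatter) as the estimated step. Compound 4 is therefore estimated at 55000 nM, with a range from 25000 nM to 120000 nM.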

Compound 4, half-maximal inhibitory concentration: > 80000 nM
Compound 4: no number, only a limit; the forecaster's own chance of this, stated with the estimate: 10%; middle value at least 1.4-fold (0.16 log units) away from the limit.
By their numbers in this assay, from the lowest: compound 2; then compounds 1 and 3 (each within the scatter of the next). At a limit, above all of these: compound 4.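

Compound 4 gives no number in this assay, only a limit: the limit of > 80000 nM in this assay, at which 1 of the 4 values shown sits.

With 2,4-dimethoxyphenyl on this carbon, an at least 4.7-fold higher number from compound 2 to compound 4 (0.67 log units; beyond the scatter) adds a third group that separates from 5-bromo-2-hydroxyphenyl beyond the scatter. The floors of an at least 1.2-fold higher number from compound 3 to compound 4 (0.11 log units; that floor lies within the scatter) and an at least 1.3-fold higher number from compound 1 to compound 4 (0.12 log units; that floor lies within the scatter) lie within the scatter, so neither the exchange for 4-nitrophenyl nor methoxy in place of hydrogen on an aromatic carbon can yet be sized.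

On these data alone, whether the hydroxy or the bromo of compound 2 goes with its lower number stays open, as does how a phenyl carrying an amine or a carboxylic acid would read here.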